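Series notes: pyridin-2-yl to oxolan-3-yl

The source may hold more compounds than are shown below. What is called first, only, known or untested is meant among the compounds shown, and "the series" means these compounds.

Measured in a physicochemical assay for solubility, measured as kinetic solubility, at pH 7.4; a lower number here means a less soluble compound, a higher number a more soluble compound:
compound 1 `COc1cc(N2CCNCC2)ccc1Nc1nc(NC2CCCCC2)c2nc[nH]c2n1`: 19000 nM
compound 2 `COc1cc(N2CCN(Cc3ccccn3)CC2)ccc1Nc1nc(NC2CCCCC2)c2nc[nH]c2n1`: 38000 nM

Among the measured compounds shown here, compound 2 sits level with compound 1, the only other measured compound. Compound 3 `COc1cc(N2CCN(CC3CCOC3)CC2)ccc1Nc1nc(NC2CCCCC2)c2nc[nH]c2n1` keeps the shared core and differs from compound 2 in one group: oxolan-3-yl in place of pyridin-2-yl on a saturated chain carbon bound to an amine nitrogen in a ring. Cut one bond further out, this reads (pyridin-2-yl)methyl to (oxolan-3-yl)methyl. For the measured compounds named here, no measured step exchanges these two groups. Going by the values given here, the nearest evidence is a 2.0-fold higher number from compound 1 to compound 2 (0.30 log units; within the scatter), the sole measured step, which placed (pyridin-2-yl)methyl in place of hydrogen on an amine nitrogen in a ring. On that thin basis, no step beyond the scatter is expected in either direction in this assay, and the estimated change is a 1.1-fold lower number from compound 2 to compound 3 (0.04 log units; within the scatter). For compound 3 the expected value is 35000 nM, with an estimated range from 14000 nM to 80000 nM.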

Compound 3, solubility: 5000 nM
Compound 3: middle estimate off by 7.0-fold (0.85 log units), on the high side, outside the stated range (below it).
By their numbers in this assay, from the lowest: compound 3; then compounds 1 and 2 (each within the scatter of the next).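

In this assay, among the compounds shown here, the ring on the saturated chain carbon bound to an amine nitrogen in a ring proves not to be interchangeable: oxolan-3-yl in place of pyridin-2-yl gives a 7.6-fold lower number from compound 2 to compound 3 (0.88 log units; beyond the scatter) (beyond the scatter, as printed), and this is the sole exchange of the two rings at hand. Measured against the hydrogen of compound 1, (oxolan-3-yl)methyl gives a 3.8-fold lower number from compound 1 to compound 3 (0.58 log units; beyond the scatter) and so departs from the parent, whereas (pyridin-2-yl)methyl stayed within the scatter with a 2.0-fold higher number from compound 1 to compound 2 (0.30 log units; within the scatter) on the same nitrogen. Nothing at hand accounts for the gap between the two rings.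

This exchange alters ring size, aromatic character and the ring hetero atom together, so these cannot be separated. A piperidin-4-yl or morpholin-2-yl ring on the same chain carbon would help to separate them, and an open-chain ether or a primary amine would test whether any ring is needed.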